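Replacing pyridin-3-yl on an amide-type nitrogen

This account rests on a few compounds, and the source may have more. Where it says the series, first, only, none or still open, it means among the compounds named here.

Compound 1 `CC(C)(C)c1cc(C(=O)Nc2nc(CNS(C)(=O)=O)cs2)n(Cc2ccccc2)n1` gives 3.1 ug/mL
Compound 2 `CC(C)(C)c1cc(C(=O)Nc2cccnc2)n(Cc2ccccc2)n1` gives 6.3 ug/mL

In a physicochemical assay for solubility, read by nephelometry, measured as kinetic solubility, at pH 6.5 (on this read-out higher numbers stand for higher solubility and lower numbers for lower solubility), compound 2 stands highest of the two at 6.3 ug/mL, and its gap to compound 1 lies beyond the usual scatter of repeat measurements. Compound 3 `CNCc1csc(NC(=O)c2cc(C(C)(C)C)nn2Cc2ccccc2)n1` has not yet been measured. It differs from compound 2 by one swap on an amide-type nitrogen, where 4-((methylamino)methyl)-1,3-thiazol-2-yl takes the place of pyridin-3-yl (4-((methylamino)methyl)-1,3-thiazol-2-yl in place of pyridin-3-yl on an amide-type nitrogen). Among the measured compounds shown here, no measured pair shows this swap, so the expectation rests on the structural change alone and stays loose. In this assay, a clear upward move beyond the scatter is expected, and the estimated change is a 4.0-fold higher number from compound 2 to compound 3 (0.60 log units; beyond the scatter), with a wide margin. For compound 3 the estimated value is 25 ug/mL, with an expected range of 6 ug/mL to 90 ug/mL.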

Compound 3, solubility: 12.5 ug/mL
Estimate against measurement, compound 3: 2.0-fold (0.30 log units) above; the measured number falls inside the stated range.
By their numbers in this assay, from the lowest: compound 1; then compounds 2 and 3 (each within the scatter of the next).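

In this assay, 4-((methylamino)methyl)-1,3-thiazol-2-yl in place of pyridin-3-yl on the amide-type nitrogen gives a 2.0-fold higher number from compound 2 to compound 3 (0.30 log units; within the scatter), so these two quite different groups cannot be told apart in this read-out. Methyl in place of methylsulfonyl on the amine nitrogen gives a 4.0-fold higher number from compound 1 to compound 3 (0.61 log units; beyond the scatter), a modest step showing that the group on that outer nitrogen can shift the number even with the rest of the molecule unchanged. Nothing measured here explains either step.

From the compounds shown here alone, it remains open how a primary amine, a dimethylamino group or an acetyl group would read on that same outer position. Going by these compounds, it is also open whether a longer chain between the amine nitrogen and the ring, or a carboxylic acid in place of the amine, would move the number further.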